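A few compounds are considered here, and "the series" means these few. Any claim that something is new, unique, unknown or untested is made for them only; others in the source may bear on it.

Measured so far, with half-maximal cytotoxic concentrations:

Compound 1 `COc1cc(/C=C2\Cc3ccccc3/C(=C\c3ccc([N+](=O)[O-])cc3)C2=O)ccc1O` — in a functional assay on HPLF cells (Homo sapiens) for cytotoxicity (on this read-out lower numbers stand for higher toxicity in this test and higher numbers for lower toxicity in this test), compound 1 gives 21000 nM.
Compound 2 `COc1ccc(/C=C2\Cc3ccccc3/C(=C\c3ccc([N+](=O)[O-])cc3)C2=O)cc1OC` — for compound 2 only a limit is reported, > 400000 nM.
Compound 3 `O=C1/C(=C/c2ccc(O)cc2)CCC/C1=C\c1ccc([N+](=O)[O-])cc1` — for compound 3 likewise only a limit, > 400000 nM.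

Compound 4 `COc1ccc(/C=C2\CCC/C(=C\c3ccc([N+](=O)[O-])cc3)C2=O)cc1` is not yet measured.

Among the measured compounds shown here, the one measured step within the set is methyl in place of hydrogen on an oxygen on an aromatic ring. It gave an at least 19-fold higher number from compound 1 to compound 2 (1.27 log units; beyond the scatter). The size of that step is bounded only from one side, since compound 2 is reported as a limit; the same limit recurs across the set, (the limit of > 400000 nM in this assay, at which 2 of the 3 values shown sit).

Compound 4 carries the same change relative to compound 3: methyl in place of hydrogen on an oxygen on an aromatic ring. The place is described in the same words for both pairs. How the core of compound 1 and the core of compound 3 differ is not broken down here.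

Compound 3 already sits at the limit of the assay, so a step upward from it cannot be read as a number. The expected step to compound 4 is a step that the limit leaves unreadable from compound 3 to compound 4, resting on the direction of an at least 19-fold higher number from compound 1 to compound 2 (1.27 log units; beyond the scatter) and on the fact that compound 3 reports > 400000 nM as a limit. The estimate for compound 4 is therefore 450000 nM, with an expected range from 120000 nM to 1500000 nM, and most likely the assay will again report only a limit for compound 4.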

Compound 4, half-maximal cytotoxic concentration: > 400000 nM
Compound 4 ended at the assay's limit; the forecaster's own chance of this, stated with the estimate: 85%; the middle value is on the limit's open side.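

In this assay compound 4 gives > 400000 nM, which is a limit. Compound 3 also sits at a limit, so no step can be read between compound 3 and compound 4, and the limit recurs across the series: the limit of > 400000 nM in this assay, at which 3 of the 4 values shown sit.

The compounds shown leave open whether hydroxy to methoxy changes the read-out at all on the core of compound 3.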